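Swapping Bromine for Iodine on a Urea Series

The source may hold more compounds than are shown below. What is called first, only, known or untested is meant among the compounds shown, and "the series" means these compounds.

Three compounds from one study share a common core, each carrying a urea that links the core to an aromatic ring bearing a single halogen. Within the data shown here, compound 1 `CC(C)(C)C[N+]1(C)CCc2c(sc(NC(=O)Nc3ccc(Cl)cc3)c2C(N)=O)C1` is the first of them. In a functional assay (strain AB) with Danio rerio as the target, read by microscopy, with a stated time of 1 h (a higher number here means that more compound is needed for the effect, a lower number that less compound is needed), compound 1 gives 290 nM. Compound 2 `CCN1CCc2c(sc(NC(=O)Nc3ccc(Br)cc3)c2C(N)=O)C1` gives 3130 nM in this assay, and compound 3 `NC(=O)c1c(NC(=O)Nc2ccc(Cl)cc2)sc2c1CCN(CC1CCC1)C2` gives 1360 nM.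

Compound 2 therefore stands at the highest number of the three, meaning that the most compound is needed for the effect. Its nearest neighbour is compound 3, whose number is lower by an amount beyond the usual scatter; compound 1 sits furthest away, with a number lower by far more than the scatter.

The next compound, compound 4 `CCN1CCc2c(sc(NC(=O)Nc3ccc(I)cc3)c2C(N)=O)C1`, has not yet been measured. It differs from compound 2 in one place: iodo in place of bromo on an aromatic carbon. Among the measured compounds shown here, no two measured compounds differ in only one place, so no measured step shows what this kind of swap does here. Since both groups are single halogen atoms at the same position, the step from compound 2 to compound 4 is expected to be small, a 1.3-fold lower number from compound 2 to compound 4 (0.10 log units; within the scatter), and likely within the scatter. Compound 4 is estimated at 2500 nM, with a range from 1000 nM to 7000 nM.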

Compound 4, half-maximal effective concentration: 1620 nM
Estimate against measurement, compound 4: 1.5-fold (0.19 log units) above; measured number inside the range.
By their numbers in this assay, from the lowest: compound 1; then compounds 3, 4 and 2 (each within the scatter of the next, the first and the last beyond it).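

Among these compounds, compounds 2 and 4 are the first pair here to differ in only one place, so they give the first direct reading of a change at this position on the aromatic ring, para to a large group. In this assay, iodo in place of bromo gives a 1.9-fold lower number from compound 2 to compound 4 (0.29 log units; within the scatter), a step that does not separate the two compounds, so this position accepts either halogen without a clear shift in the number. Nothing available here explains this result or links it to any property of the two halogens.

Among the compounds shown here, compounds 1 and 3 differ from both compound 2 and compound 4 in more than one place, so no steps to them can be read, and the part played by the other group on the shared core remains unknown. Going by these compounds, it also remains open whether a fluoro, methoxy or nitrile group at this same aromatic carbon would leave the number as little separated as iodo does, or whether this position responds only to a larger change of group.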